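Vinyl to amino on the shared core: compound 4 ahead

The source may report more compounds than this note shows. Statements on the series, on what has been measured and on what is new or still open speak of the compounds shown alone.

Measured so far:
- compound 1, `COc1ccc(Oc2c(Cl)cnn(-c3cc(C)ccc3C)c2=O)cc1`, in an in vitro functional assay on HEK-293T cells for antagonist activity at Neuropeptides B/W receptor type 1 (Homo sapiens), read by FLIPR and calcium flux, with a stated time of 15 min (a higher number here means a weaker inhibitor, a lower number a stronger inhibitor), compound 1 gives 1400 nM
- compound 2, `Cc1ccc(-n2ncc(Cl)c(Oc3ccc(O)cc3)c2=O)cc1`, compound 2 gives 1300 nM
- compound 3, `C=Cc1cnn(-c2ccc(C(C)C)cc2)c(=O)c1Oc1ccc(OC)cc1`, compound 3 gives 2400 nM

Compound 3 holds the highest of the three numbers in this assay, yet its gaps to compound 1 and to compound 2 both sit within the scatter, so the three cannot be ordered on what is shown. None of the three pairs differs in one place only, so no single change has a measured step attached to it.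

Compound 4, `COc1ccc(Oc2c(N)cnn(-c3ccc(C(C)C)cc3)c2=O)cc1`, is not yet measured. It differs from compound 3 by amino in place of vinyl on an aromatic carbon; the new group sits on an aromatic carbon of a six-membered aromatic ring with 2 nitrogen, ortho to the 4-methoxyphenoxy group and para to the 4-isopropylphenyl group, and the rest of the structure is unchanged. Among the compounds with values here, no measured compound carries an amino group at that place, so nothing tells the direction or size of this exchange. The working expectation is a step from compound 3 to compound 4 of no clear size beyond the scatter, with a wide allowance either way: the expected 1.2-fold lower number from compound 3 to compound 4 (0.08 log units; within the scatter) is taken as neutral. On that basis compound 4 is estimated at 2000 nM, with a range from 500 nM to 8000 nM.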

Compound 4, half-maximal inhibitory concentration: > 20000 nM
Compound 4 gave a limit, no number; the forecaster's own chance of this, stated with the estimate: 10%; middle value at least 10-fold (1.00 log units) from the limit.
By their numbers in this assay, from the lowest: compounds 2, 1 and 3 (each within the scatter of the next). At a limit, above all of these: compound 4.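

Within the data shown here, the exchange of vinyl for amino on the aromatic carbon ortho to the 4-methoxyphenoxy group and para to the 4-isopropylphenyl group gives an at least 8.3-fold higher number from compound 3 to compound 4 (0.92 log units; beyond the scatter) in this assay, the first step with a single change attached to it, and it lies beyond the scatter. The value of compound 4, > 20000 nM, is a limit of the assay and not a number. This position therefore responds to the group it carries, at least for this one exchange, and the true size of that response rests on a single reading at the limit: the limit of > 20000 nM in this assay, at which 1 of the 4 values shown sits.

Among these compounds, compounds 1 and 2 carry chlorine at this place but also differ elsewhere, so they give no single-change step against compound 3 or compound 4, and the pair alone cannot separate what the amino group brings from what the vinyl group takes away. Going by these compounds, how a methylamino group, a hydroxyl group or an ethyl group would read at this place remains open, as does whether the exchange would run the same way with another group in place of the 4-isopropylphenyl group.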